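Butyl to octyl on the ring oxygen

A few compounds are considered here, and "the series" means these few. Any claim that something is new, unique, unknown or untested is made for them only; others in the source may bear on it.

In a functional assay, with stated times of 30 s and 6 min, in the presence of a further agent that is not named here (on this read-out lower numbers stand for stronger inhibition and higher numbers for weaker inhibition), compound 1 `COc1cc(O)c(C(C)=O)cc1Br` gives 15600000 nM as its half-maximal value. Compound 2 `CCCCOc1cc(OC)c(Br)cc1C(C)=O` gives 38200000 nM and holds the higher of the two numbers, making it the weaker inhibitor of the pair. Compound 3 `CCCCCCCCOc1cc(OC)c(Br)cc1C(C)=O` differs from compound 2 by butyl in place of hydrogen on a saturated chain carbon, four bonds along the chain from an oxygen on an aromatic ring and so carries butyl in place of hydrogen on a saturated chain carbon, four bonds along the chain from an oxygen on an aromatic ring. Among the measured compounds shown here, the only measured step bearing on this change is a 2.4-fold higher number from compound 1 to compound 2 (0.39 log units; beyond the scatter) for butyl in place of hydrogen on an oxygen on an aromatic ring, and it is modest and beyond the scatter. One step sets no trend, but another modest rise is expected in this assay for the longer chain. The estimated change is a 1.6-fold higher number from compound 2 to compound 3 (0.20 log units; within the scatter) on this reasoning. Compound 3 is estimated at 60000000 nM with an expected range of 22000000 nM to 160000000 nM for that value.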

Compound 3, half-maximal inhibitory concentration: 30900000 nM
For compound 3 the middle estimate is 1.9-fold (0.29 log units) above the measured one; measured number inside the range.
By their numbers in this assay, from the lowest: compounds 1, 3 and 2 (each within the scatter of the next, the first and the last beyond it).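

In this assay, butyl in place of hydrogen on a saturated chain carbon, four bonds along the chain from an oxygen on an aromatic ring, gives a 1.2-fold lower number from compound 2 to compound 3 (0.09 log units; within the scatter), so compound 2 and compound 3 stand within the scatter of each other. The earlier step, a 2.4-fold higher number from compound 1 to compound 2 (0.39 log units; beyond the scatter), lay beyond the scatter; at this further place on the chain, the added butyl does not separate the two compounds, so the chain tolerates this change on this read-out without a measurable shift. No measurement on hand gives a reason for this result.

On these data alone, whether an amine or a carboxylic acid in place of butyl at this same place would also stay within the scatter remains open. As far as these compounds go, a longer chain is equally open, since two steps fix no trend for the series.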